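Swapping the aryl on the triazole nitrogen of compound 3

This account rests on a few compounds, and the source may have more. Where it says the series, first, only, none or still open, it means among the compounds named here.

The compounds share one core, carrying a nitrile, an amine and a lactam, with a benzyl-type arm that ends in a triazole bearing an aryl group. Compound 1 `N#CC1=C(N)Oc2c(c3nc4ccccc4nc3c3ccccc23)C12C(=O)N(Cc1cnnn1-c1ccccc1Br)c1ccccc12` carries a 2-bromophenyl there; compound 2 `CCOc1ccc(-n2nncc2CN2C(=O)C3(C(C#N)=C(N)Oc4c3c3nc5ccccc5nc3c3ccccc43)c3ccccc32)cc1` a 4-ethoxyphenyl; compound 3 `N#CC1=C(N)Oc2c(N)cc3nc4ccccc4nc3c2C12C(=O)N(Cc1cnnn1-c1cccc(C(F)(F)F)c1)c1ccccc12` a 3-(trifluoromethyl)phenyl on a core that also bears an amino group. In a functional assay on A549 cells (Homo sapiens) for antiproliferative activity, read by MTT assay, with a stated time of 48 h (on this read-out higher numbers stand for weaker inhibition and lower numbers for stronger inhibition), compound 1 gives only a limit, > 50000 nM (the limit of > 50000 nM in this assay, at which 1 of the 3 values shown sits). Compound 2 gives 25200 nM in this assay. Compound 3 gives 5400 nM, the lowest of the two numbers, separated from compound 2 by a gap beyond the scatter.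

Compound 4 `N#CC1=C(N)Oc2c(N)cc3nc4ccccc4nc3c2C12C(=O)N(Cc1cnnn1-c1ccc(Cl)cc1[N+](=O)[O-])c1ccccc12` differs from compound 3 only at the aryl on the triazole: 4-chloro-2-nitrophenyl in place of 3-(trifluoromethyl)phenyl on an aromatic nitrogen. The one measured step at this same position, an at least 1.9-fold lower number from compound 1 to compound 2 (0.29 log units; that floor lies within the scatter), was small and its floor lies within the scatter, so the aryl on the triazole has so far shown little leverage. On that basis compound 4 is expected to stay close to compound 3, with a 1.3-fold higher number from compound 3 to compound 4 (0.11 log units; within the scatter) expected to fall within the scatter. Compound 4 is therefore estimated at 7000 nM in this assay, within 2500 nM to 20000 nM.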

Compound 4, half-maximal inhibitory concentration: > 50000 nM
Compound 4: no number, only a limit; the forecaster's own chance of this, stated with the estimate: 10%; at least 7.1-fold (0.85 log units) between middle value and limit.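

The swap to 4-chloro-2-nitrophenyl gives an at least 9.2-fold higher number from compound 3 to compound 4 (0.96 log units; beyond the scatter) in this assay, so the aryl on the triazole nitrogen can matter a great deal in this series. The earlier step at this position, an at least 1.9-fold lower number from compound 1 to compound 2 (0.29 log units; that floor lies within the scatter), could not show that, since its floor stayed within the scatter and it was made on a core without the amino group. Compound 4 gives a limit and not a number, so the true size of the step remains unknown, and two of the compounds now sit at that limit: the limit of > 50000 nM in this assay, at which 2 of the 4 values shown sit.

The entering aryl brings both a chlorine and a nitro group, and the compounds shown do not separate the two, so it stays open whether either alone accounts for the step, or whether an amine in place of the nitro group or a plain phenyl would keep the activity of compound 3. With only two aryl groups shown on the amino-bearing core, it also remains open whether 3-(trifluoromethyl)phenyl is a particularly favourable choice there or whether 4-chloro-2-nitrophenyl is an unusually poor one.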